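Sulfonyl to Sulfanyl on the Shared Core of Compound 1

The source may report more compounds than this note shows. Statements on the series, on what has been measured and on what is new or still open speak of the compounds shown alone.

Compound 1 `CN(C)c1ccc(/C=C(\C(=O)c2ccc(C(=O)O)cc2)S(=O)(=O)Cc2ccc(Cl)cc2)cc1` was examined in a functional assay on DU-145 cells (Homo sapiens) for inhibition, read by trypan blue exclusion, with a stated time of 96 h; a higher number here means a weaker inhibitor of growth, a lower number a stronger inhibitor of growth. There compound 1 gives > 100000 nM, which is a limit of the assay and not a number. Compound 2 `O=C(/C(=C\c1c(O)cc(O)cc1O)Sc1ccccc1Br)c1ccc(Br)cc1` gives > 100000 nM in this assay, again only a limit. Compound 3 `COc1cc(OC)c(/C=C(\C(=O)c2ccc(Br)cc2)S(=O)(=O)c2ccc(C)cc2)c(OC)c1` gives > 100000 nM in this assay, also a limit. Every value shown therefore sits at the limit of > 100000 nM in this assay, at which 3 of the 3 values shown sit, and compound 1 stands there with the others. Compound 4 `CN(C)c1ccc(/C=C(/SCc2ccc(Cl)cc2)C(=O)c2ccc(C(=O)O)cc2)cc1` differs from compound 1 in a single place: (4-chlorobenzyl)sulfanyl in place of (4-chlorobenzyl)sulfonyl on a double-bonded chain carbon bound to a carbonyl carbon and a double-bonded chain carbon. Going by the values given here, no step between measured compounds is known, so the account expects no change beyond the scatter in this assay, noting that compound 2, which also carries a sulfanyl group, gives > 100000 nM. Compound 4 is thus estimated at 150000 nM, between 30000 nM and 600000 nM. The expected step that the limit leaves unreadable from compound 1 to compound 4 is essentially flat.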

Compound 4, concentration for 50% growth inhibition: 1000 nM
Compound 4: the middle estimate sits 150-fold (2.18 log units) above what was measured; measured number below the stated range.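

In this assay, putting (4-chlorobenzyl)sulfanyl in place of (4-chlorobenzyl)sulfonyl on a double-bonded chain carbon bound to a carbonyl carbon and a double-bonded chain carbon gives an at least 100-fold lower number from compound 1 to compound 4 (2.00 log units; beyond the scatter). Going by these compounds alone, on this core, then, the position responds strongly to this one change, which the earlier compounds could not show. Compound 4 is the only compound shown with a readable number, and the others stand at a limit: the limit of > 100000 nM in this assay, at which 3 of the 4 values shown sit.

On these data alone, whether a sulfinyl group at this place would read closer to compound 4 or to compound 1 stays open. So does whether the exchange holds once the carboxylic acid gives way to an amide.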